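The source may hold more compounds than are shown below. What is called first, only, known or untested is meant among the compounds shown, and "the series" means these compounds.

Working notes on the series. Compound 1 `c1ccc(-c2cccc3c2CCC3c2ncc[nH]2)nc1` is tested in a functional assay on CHO cells for agonist activity at Alpha-1D adrenergic receptor (Homo sapiens), read by FLIPR and calcium flux; a lower number here means that less compound is needed, a higher number that more compound is needed for the effect. In this assay compound 1 returns only a limit, > 10000 nM. Compound 3 `Cc1c(OCC2=NCCN2)ccc(Cl)c1NS(C)(=O)=O` likewise gives only a limit in this assay, > 10000 nM; this is the limit of the limit of > 10000 nM in this assay, at which 2 of the 3 values shown sit. For the measured compounds named here, compound 2 `c1cc(-c2ccn[nH]2)c2c(c1)C(c1ncc[nH]1)CC2` gives 336 nM in this assay, and the single measured step, an at least 29-fold lower number from compound 1 to compound 2 (1.47 log units; beyond the scatter), is the only one bearing on the present change. Compound 4 `Cn1nccc1-c1cccc2c1CCC2c1ncc[nH]1` differs from compound 1 by 1-methyl-1H-pyrazol-5-yl in place of pyridin-2-yl on an aromatic carbon. The measured step from compound 1 to compound 2 introduced the same five-membered ring with two hetero atoms, though bearing a hydrogen-bond donor that compound 4 lacks, so a smaller gain is expected here, an at least 4.0-fold lower number from compound 1 to compound 4 (0.60 log units; beyond the scatter). For compound 4 in this assay the estimate is 2500 nM, with a range from 500 nM to 10000 nM.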

Compound 4, half-maximal effective concentration: > 10000 nM
Compound 4 ended at the assay's limit; the forecaster's own chance of this, stated with the estimate: 35%; middle value at least 4.0-fold (0.60 log units) from the limit.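

At this position, the hydrogen on the aromatic nitrogen of the five-membered ring decides the outcome in this assay, with methyl in its place giving an at least 29-fold higher number from compound 2 to compound 4 (1.47 log units; beyond the scatter). A five-membered aromatic ring with 2 hetero atoms is therefore not sufficient on its own to give a readable value. The step from compound 1 to compound 4 cannot be read, as both values are limits: the limit of > 10000 nM in this assay, at which 3 of the 4 values shown sit.

The compounds shown do not separate the loss of the hydrogen from the presence of the methyl. From the compounds shown here alone, whether ethyl on that nitrogen, or an amine on the pyridin-2-yl ring, would give a readable value remains open.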